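An Ester Arm Added to a Weakly Active Core

The source may report more compounds than this note shows. Statements on the series, on what has been measured and on what is new or still open speak of the compounds shown alone.

Compound 1 `COc1cccc2cc(-c3ccccc3)c(O)nc12` and compound 2 `COc1ccc(-c2cc3c(OC)cc(OC)cc3n(C)c2=O)cc1` were both tested in a functional assay on U-373MG ATCC cells for cytotoxicity against U373 MG (Homo sapiens), read by colorimetric assay and MTT assay; on this read-out lower numbers stand for stronger inhibition and higher numbers for weaker inhibition. In this assay compound 1 gives 10000 nM. In this assay compound 2 gives 10000 nM, level with compound 1 at the digits shown, so the two values lie within the scatter of each other and neither compound can be called the more active one. Compound 3 `CCOC(=O)Cn1c(=O)c(-c2ccc(OC)cc2)cc2c(OC)cc(OC)cc21` has not yet been measured in this assay. It differs from compound 2 in one place: ethoxycarbonyl in place of hydrogen on a saturated chain carbon bound to an aromatic nitrogen. Going by the values given here, no step between measured compounds involves a change of this kind, so nothing here indicates its size or direction. Among the compounds with values here, the estimated step of no change at the digits printed from compound 2 to compound 3 (within the scatter) is none beyond the scatter, since the only guide is the value of compound 2 at 10000 nM. Compound 3 is therefore expected to give about 10000 nM, with a range from 5000 nM to 20000 nM.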

Compound 3, half-maximal inhibitory concentration: 10000 nM
Estimate against measurement, compound 3: no gap at the digits printed; the measured number falls inside the stated range.
By their numbers in this assay, from the lowest: compounds 1, 2 and 3 (each within the scatter of the next).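

Putting ethoxycarbonyl in place of hydrogen on a saturated chain carbon bound to an aromatic nitrogen gives no change at the digits printed from compound 2 to compound 3 (within the scatter) in this assay. Going by these compounds alone, this is the first step read at this position, and it shows that the change from methyl to (ethoxycarbonyl)methyl, which adds a sizeable arm with no ring and no net charge, brings neither a gain nor a loss beyond the scatter. Nothing measured here bears on why the number stays level.

On these data alone, whether a carboxylic acid or an amine at the end of this arm, or a longer chain at the same place, would move the number away from the level of compound 3 at 10000 nM remains open. Also open, as far as these compounds go, is whether the same arm would leave the number level on the core of compound 1.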